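Benzylsulfanyl in place of pyrazinylmethoxy: working notes

This account rests on a few compounds, and the source may have more. Where it says the series, first, only, none or still open, it means among the compounds named here.

Three compounds carry numbers in a functional assay on HEK293 cells for positive allosteric modulation of metabotropic glutamate receptor 5 (Homo sapiens), read by FLIPR and calcium flux; a lower number here means that less compound is needed, a higher number that more compound is needed for the effect. Compound 1 `O=C(COCc1ccccc1)N1CCN(c2ccc(F)cc2Cl)CC1` gives 270 nM. Compound 2 `O=C(COCc1ccncc1)N1CCN(c2ccc(F)cc2F)CC1` gives 4600 nM. Compound 3 `O=C(COCc1cnccn1)N1CCN(c2ccc(Cl)cc2Cl)CC1` gives 5200 nM, the highest of the three numbers; it lies within the scatter of compound 2, and its gap to compound 1 is beyond the scatter, compound 1 needing far less compound.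

Compound 4 `O=C(CSCc1ccccc1)N1CCN(c2ccc(Cl)cc2Cl)CC1` is not yet measured. It differs from compound 3 in one place: benzylsulfanyl in place of (pyrazin-2-yl)methoxy on a saturated chain carbon bound to a carbonyl carbon. Compound 4 thus carries a six-membered aromatic ring of carbon only, as does compound 1, which gives 270 nM. Compound 2 and compound 3 each carry a ring with hetero atoms and sit well higher. Going by the values given here, no measured pair separates the sulfur-for-oxygen part of the change from the ring part, so the expectation rests on compound 1 alone and is rough. The step in this assay is expected to be a decrease beyond the scatter, estimated at a 12-fold lower number from compound 3 to compound 4 (1.06 log units; beyond the scatter). Compound 4 is estimated at 450 nM in this assay, with a range of 100 nM to 2500 nM.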

Compound 4, half-maximal effective concentration: 7100 nM
Beside the measured number, compound 4's estimate is 16-fold (1.20 log units) below it, outside the stated range (above it).
By their numbers in this assay, from the lowest: compound 1; then compounds 2, 3 and 4 (each within the scatter of the next).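

In this assay, benzylsulfanyl in place of (pyrazin-2-yl)methoxy on a saturated chain carbon bound to a carbonyl carbon gives a 1.4-fold higher number from compound 3 to compound 4 (0.14 log units; within the scatter), so this single change leaves no readable shift, even though a ring with 2 hetero atoms gives way to a ring of carbon only and the oxygen gives way to sulfur. A six-membered aromatic ring of carbon only at this place therefore does not by itself bring a low number. Nothing available explains why the step is so small.

Going by these compounds alone, whether the sulfur part and the ring part of the change each have no effect or offset one another remains open, as no pair separates them. Also open, going by these compounds, is how the series responds at this place to a longer chain such as phenethylsulfanyl, or to an amine or a carboxylic acid.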